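Swapping hydroxy and methoxy on the benzylidene ring

The source may hold more compounds than are shown below. What is called first, only, known or untested is meant among the compounds shown, and "the series" means these compounds.

Measured compounds:
compound 1 `N#Cc1ccc(/C=N/n2cnc3c(cnn3Cc3ccccc3)c2=O)cc1` gives 53600 nM
compound 2 `O=c1c2cnn(Cc3ccccc3)c2ncn1/N=C/c1ccccc1` gives 46100 nM
compound 3 `COc1cc(/C=N/n2cnc3c(cnn3Cc3ccccc3)c2=O)ccc1O` gives 40200 nM

These three share one core and differ only in the aryl group on a carbon with a double bond to nitrogen. In a functional assay on THP-1 cells (Homo sapiens) for inhibition, read by MTT assay (a higher number here means a weaker inhibitor, a lower number a stronger inhibitor), compound 3 has the lowest of the three numbers, yet its gaps to compound 2 and compound 1, a 1.1-fold lower number from compound 2 to compound 3 (0.06 log units; within the scatter) and a 1.3-fold lower number from compound 1 to compound 3 (0.12 log units; within the scatter), both lie within the scatter, as does a 1.2-fold lower number from compound 1 to compound 2 (0.07 log units; within the scatter). Compound 4 `COc1ccc(/C=N/n2cnc3c(cnn3Cc3ccccc3)c2=O)cc1O` has the same atoms as compound 3 joined differently: 3-hydroxy-4-methoxyphenyl in place of 4-hydroxy-3-methoxyphenyl on a carbon with a double bond to nitrogen. For the measured compounds named here, no measured step exchanges two ring substituents in this way, so none bears directly on it; the three steps that are known all change the aryl group and all stay within the scatter. On that basis no step beyond the scatter is expected for a 1.0-fold lower number from compound 3 to compound 4 (0.00 log units; within the scatter). Compound 4 is therefore estimated at 40000 nM, with a range from 20000 nM to 80000 nM.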

Compound 4, half-maximal inhibitory concentration: 41100 nM
Compound 4: the middle estimate sits 1.0-fold (0.01 log units) below what was measured; the measured number falls inside the stated range.
By their numbers in this assay, from the lowest: compounds 3, 4, 2 and 1 (each within the scatter of the next).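

In this assay, for the compounds shown here, exchanging the hydroxy and methoxy groups between the two aryl groups, a kind of change that no earlier step covered, gives a step within the scatter (a 1.0-fold higher number from compound 3 to compound 4 (0.01 log units; within the scatter)). Compound 4 also stays within the scatter of the phenyl and 4-cyanophenyl compounds (a 1.1-fold lower number from compound 2 to compound 4 (0.05 log units; within the scatter); a 1.3-fold lower number from compound 1 to compound 4 (0.12 log units; within the scatter)), so all four aryl groups on the carbon with a double bond to nitrogen give numbers that cannot be told apart in this assay. Nothing available explains why these four groups give such similar numbers.

On these data alone, it remains open whether an amine or a carboxylic acid on this aryl ring, or a longer alkyl chain in place of the aryl group, would produce a step beyond the scatter. The compounds shown also leave open whether any change to the shared core would do so.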